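The source may report more compounds than this note shows. Statements on the series, on what has been measured and on what is new or still open speak of the compounds shown alone.

Measured so far in a functional assay on MV4-11 cells (Homo sapiens) for inhibition, read by resazurin assay, with a stated time of 72 h; on this read-out higher numbers stand for weaker inhibition of growth and lower numbers for stronger inhibition of growth:
- compound 1 `O=C1NCCC12CCN(c1c(Cl)cncc1-c1cccs1)CC2`: 480 nM
- compound 2 `O=C1NCCC12CCN(c1c(Cl)cncc1-c1ccsc1)CC2`: 190 nM
- compound 3 `Cc1csc(-c2cncc(Cl)c2N2CCC3(CCNC3=O)CC2)c1`: 650 nM

Compound 1 stands at the high end of these numbers together with compound 3, the two lying within the scatter of each other. Compound 2 lies clearly lower, with a 2.5-fold lower number from compound 1 to compound 2 (0.40 log units; beyond the scatter) as the step.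

Compound 4 `Cc1ccc(-c2cncc(Cl)c2N2CCC3(CCNC3=O)CC2)s1` is not yet measured. It differs from compound 1 in one place (methyl in place of hydrogen on an aromatic carbon), which is methyl in place of hydrogen on an aromatic carbon, next to the ring sulfur, or thiophen-2-yl to 5-methylthiophen-2-yl.

Among the measured compounds shown here, the nearest precedent is the same kind of change in compound 3, which carries 4-methylthiophen-2-yl, with a 1.4-fold higher number from compound 1 to compound 3 (0.13 log units; within the scatter) as the step. For the measured compounds named here, no measured compound has the methyl at the place it occupies in compound 4, so this precedent is indirect. a 3.4-fold higher number from compound 2 to compound 3 (0.53 log units; beyond the scatter) also changes the point of attachment and bears less directly on this case. No step beyond the scatter is therefore expected.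

The expected step is a 1.3-fold higher number from compound 1 to compound 4 (0.10 log units; within the scatter) in this assay. The estimated value for compound 4 is 600 nM, in an expected range from 270 nM to 1300 nM.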

Compound 4, concentration for 50% growth inhibition: 650 nM
Compound 4: middle estimate off by 1.1-fold (0.03 log units), on the low side; low and high end bracket the measured number.
By their numbers in this assay, from the lowest: compound 2; then compounds 1, 3 and 4 (each within the scatter of the next).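

In this assay, methyl next to the ring sulfur on the thiophen-2-yl group of compound 1 leaves the number within the scatter (a 1.4-fold higher number from compound 1 to compound 4 (0.13 log units; within the scatter)), and the two methyl placements cannot be told apart (no change at the digits printed from compound 3 to compound 4 (within the scatter)). The separation from the thiophen-3-yl group also persists with 5-methylthiophen-2-yl (a 3.4-fold higher number from compound 2 to compound 4 (0.53 log units; beyond the scatter)), so compounds 1, 3 and 4 form one group while compound 2 alone lies clearly lower. Nothing given here accounts for this pattern.

From the compounds shown here alone, whether a larger or different group at this carbon, such as ethyl, an amine or a carboxylic acid, would shift the number remains open. Also open, going by these compounds, is whether compound 2 would keep its lower number with a methyl on its thiophen-3-yl group.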